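Fluorine pattern on the benzyl group and cytotoxicity

The source may hold more compounds than are shown below. What is called first, only, known or untested is meant among the compounds shown, and "the series" means these compounds.

Of the compounds shown here, three sharing one core have been measured in an ADME assay on MT4 cells (Homo sapiens) for cytotoxicity, read by MTT assay; on this read-out higher numbers stand for lower toxicity in this test and lower numbers for higher toxicity in this test. Compound 1 `COc1cccc2c1c(C(=O)/C=C(\O)C(=O)O)cn2Cc1cc(F)ccc1F` gives 46200 nM. Compound 2 `CCOC(=O)/C(O)=C/C(=O)c1cn(Cc2cc(F)cc(F)c2)c2cccc(OC)c12` gives 34700 nM. Compound 3 `COc1cccc2c1c(C(=O)/C=C(\O)C(=O)O)cn2Cc1ccc(F)c(F)c1F` gives 22800 nM. On these numbers compound 2 stands second highest of three, within the scatter of both neighbours, so no order among the three can be read from it.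

Compound 4 `CCOC(=O)/C(O)=C/C(=O)c1cn(Cc2ccccc2F)c2cccc(OC)c12` differs from compound 2 in one place: 2-fluorophenyl in place of 3,5-difluorophenyl on a saturated chain carbon bound to an aromatic nitrogen. Within the data shown here, the only measured step that touches the same place is a 2.0-fold lower number from compound 1 to compound 3 (0.31 log units; beyond the scatter), where one fluorine was added to the ring on the chain carbon bound to the aromatic nitrogen and the number fell modestly. The change to compound 4 goes the other way, removing one fluorine while moving the remaining one, and it also carries an ethyl ester rather than the free acid of that pair, so the bearing is loose.

Because the step of a 2.0-fold lower number from compound 1 to compound 3 (0.31 log units; beyond the scatter) was small and in the direction of fewer fluorines giving a higher number, compound 4 is expected to give a number near or somewhat above compound 2, estimated at 42000 nM with a range of 21000 nM to 84000 nM, an expected step of a 1.2-fold higher number from compound 2 to compound 4 (0.08 log units; within the scatter).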

Compound 4, half-maximal cytotoxic concentration: 63300 nM
The estimate for compound 4 lay 1.5-fold (0.18 log units) below the measured number; low and high end bracket the measured number.
By their numbers in this assay, from the lowest: compounds 3, 2, 1 and 4 (each within the scatter of the next, the first and the last beyond it).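

In this assay, the change from 3,5-difluorophenyl to 2-fluorophenyl on a saturated chain carbon bound to an aromatic nitrogen gives a 1.8-fold higher number from compound 2 to compound 4 (0.26 log units; within the scatter), so this swap, which leaves one fluorine fewer on the ring, does not separate the two ethyl esters. Among these compounds, this is the first step at this place measured with the ethyl ester, and it stands alongside a 2.0-fold lower number from compound 1 to compound 3 (0.31 log units; beyond the scatter), which was measured with the free acid, involves different fluorine patterns and lies beyond the scatter, so the two steps show no shared trend in fluorine count. No measurement here gives a reason for either step.

The compounds shown leave open whether a carboxylic acid in place of the ethyl ester would give a similar number with the 2-fluorophenyl or the 3,5-difluorophenyl group, as neither group appears here in both forms. They also leave open how a plain phenyl ring, or a chlorine atom in place of fluorine on that ring, would read in this assay.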